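This account rests on a few compounds, and the source may have more. Where it says the series, first, only, none or still open, it means among the compounds named here.

Compound 1 `O=C(NCCCNc1nc(Nc2cccnc2)ncc1C1CC1)C1CCC1` holds the lower of the two numbers recorded so far in an assay on isolated protein for inhibition of serine/threonine-protein kinase TBK1 (Homo sapiens); on this read-out higher numbers stand for weaker inhibition and lower numbers for stronger inhibition: compound 1 gives 13 nM. Compound 2 `O=C(NCCCNc1nc(Nc2ccccc2F)ncc1C1CC1)c1cccs1` differs from it in several places; in this assay compound 2 gives 820 nM, a gap well beyond the scatter. Compound 3 `Cn1ccc(Nc2ncc(C3CC3)c(NCCCNC(=O)C3CCC3)n2)n1` has not yet been measured. It differs from compound 1 in one place only: 1-methyl-1H-pyrazol-3-yl in place of pyridin-3-yl on a nitrogen on an aromatic ring. Within the data shown here, no pair of measured compounds shows this change, so nothing in the data tells how large a step it brings or in which direction. The expectation is that the step of a 1.3-fold lower number from compound 1 to compound 3 (0.11 log units; within the scatter) is small, with no clear direction, and stays within the scatter of this assay. Compound 3 is therefore expected to give about 10 nM in this assay, within a range from 3 nM to 40 nM.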

Compound 3, half-maximal inhibitory concentration: > 1000 nM
Compound 3 ended at the assay's limit; the forecaster's own chance of this, stated with the estimate: 5%; middle value at least 100-fold (2.00 log units) away from the limit.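

In this assay compound 3 gives > 1000 nM, which is a limit of the assay and not a number: the limit of > 1000 nM in this assay, at which 1 of the 3 values shown sits.

Placing 1-methyl-1H-pyrazol-3-yl in place of pyridin-3-yl on this nitrogen brings an at least 76-fold higher number from compound 1 to compound 3 (1.88 log units; beyond the scatter), so a swap between two aromatic rings of equal heavy-atom count is far from neutral here. Compound 1 and compound 2 differ in several places and could not tie their gap to any one of them, whereas this single change shows that the group at this position can by itself move the read-out strongly.

On these data alone, how far compound 3 lies past the limit stays unknown, so the full size of the step cannot be read. The compounds shown also leave open whether the step follows from the five-membered ring or from its methyl group, as they include neither an unmethylated 1H-pyrazol-3-yl nor a pyridin-4-yl at this position.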